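The source may report more compounds than this note shows. Statements on the series, on what has been measured and on what is new or still open speak of the compounds shown alone.

In a functional assay on ECa-109 cells for inhibition, with ECa-109 cell line (Homo sapiens) as the target, read by sulforhodamine B assay (on this read-out higher numbers stand for weaker inhibition and lower numbers for stronger inhibition), compound 2 `O=C1C(Nc2ccccc2)=CC(=O)c2c1nc1n2[C@H]2OC[C@@H](O)[C@H]2OC1` gives 3560 nM and compound 1 `O=C1C(Nc2ccc(I)cc2)=CC(=O)c2c1nc1n2[C@H]2OC[C@@H](O)[C@H]2OC1` gives 2530 nM, so these two values stand within the scatter of each other. Compound 3 `O=C1C(Nc2ccc(Br)cc2)=CC(=O)c2c1nc1n2[C@H]2OC[C@@H](O)[C@H]2OC1` differs from compound 2 by bromo in place of hydrogen on an aromatic carbon. For the measured compounds named here, the one measured step that bears on this change puts hydrogen in place of iodo on an aromatic carbon, a 1.4-fold higher number from compound 1 to compound 2 (0.15 log units; within the scatter), and it stays within the scatter. In this assay no change beyond the scatter is therefore expected, and the step is estimated as a 1.3-fold lower number from compound 2 to compound 3 (0.10 log units; within the scatter). Compound 3 is estimated at 2800 nM, with an expected range of 1400 nM to 5500 nM.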

Compound 3, half-maximal inhibitory concentration: 1980 nM
Beside the measured number, compound 3's estimate is 1.4-fold (0.15 log units) above it, within the range that was stated.
By their numbers in this assay, from the lowest: compounds 3, 1 and 2 (each within the scatter of the next).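

In this assay, bromo on the aromatic carbon para to a large group gives a 1.8-fold lower number from compound 2 to compound 3 (0.25 log units; within the scatter), and bromo in place of iodo at that carbon gives a 1.3-fold lower number from compound 1 to compound 3 (0.11 log units; within the scatter). A second halogen at this position thus also stays within the scatter, so hydrogen, iodo and bromo cannot be told apart here. Nothing at hand explains this result. The compounds shown leave open whether a group other than a halogen at this position, such as an amine, a methoxy group or a carboxylic acid, would move the number beyond the scatter.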